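This account rests on a few compounds, and the source may have more. Where it says the series, first, only, none or still open, it means among the compounds named here.

Measured so far in a functional assay on HEL cells (Homo sapiens); a lower number here means that less compound is tolerated, a higher number that more compound is tolerated:
- compound 1 `Cc1cn([C@@H]2O[C@H](CO[Si](C)(C)C(C)(C)C)[C@@]3(OS(=O)(=O)C=C3NCCC(N)=O)[C@H]2O[Si](C)(C)C(C)(C)C)c(=O)n(C)c1=O` — 14800 nM
- compound 2 `COC(=O)CC(=O)NC1=CS(=O)(=O)O[C@@]12[C@@H](CO[Si](C)(C)C(C)(C)C)O[C@@H](n1cc(C)c(=O)n(C)c1=O)[C@@H]2O[Si](C)(C)C(C)(C)C` — 29000 nM
- compound 3 `COC(=O)CNC1=CS(=O)(=O)O[C@@]12[C@@H](CO[Si](C)(C)C(C)(C)C)O[C@@H](n1cc(C)c(=O)n(C)c1=O)[C@@H]2O[Si](C)(C)C(C)(C)C` — 160000 nM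

Compound 1 gives the lowest of the three numbers in this assay. Compound 2 stands nearest, with a 2.0-fold higher number from compound 1 to compound 2 (0.29 log units; within the scatter); compound 3 stands furthest, with an 11-fold higher number from compound 1 to compound 3 (1.03 log units; beyond the scatter). Between those two, a 5.5-fold higher number from compound 2 to compound 3 (0.74 log units; beyond the scatter).

Compound 4 `C=C(C)C(=O)NC(=O)NC1=CS(=O)(=O)O[C@@]12[C@@H](CO[Si](C)(C)C(C)(C)C)O[C@@H](n1cc(C)c(=O)n(C)c1=O)[C@@H]2O[Si](C)(C)C(C)(C)C` shares the core of compound 1 and differs from it at one place: ((1-methylethenyl)carbonyl)carbamoyl in place of 2-carbamoylethyl on an amine nitrogen.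

The step from compound 1 to compound 2 bears most directly on this change, since it also puts a carbonyl-bearing group on the same amine nitrogen, and it stayed within the scatter. The step from compound 2 to compound 3, where the carbonyl is removed, moved the number up by a modest amount. Nothing measured shows an acylcarbamoyl group on this nitrogen. The expectation for compound 4 is therefore a small to modest move to a higher number, or none beyond the scatter, with a 2.0-fold higher number from compound 1 to compound 4 (0.31 log units; beyond the scatter). Compound 4 is estimated at 30000 nM in this assay, with a range from 10000 nM to 90000 nM.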

Compound 4, half-maximal cytotoxic concentration: 1200 nM
Estimate against measurement, compound 4: 25-fold (1.40 log units) above; the whole stated range lies above it.
By their numbers in this assay, from the lowest: compound 4; then compounds 1 and 2 (each within the scatter of the next); then compound 3.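

In this assay the amine nitrogen on the shared core can take the number downward as well as upward: ((1-methylethenyl)carbonyl)carbamoyl in place of 2-carbamoylethyl gives a 12-fold lower number from compound 1 to compound 4 (1.09 log units; beyond the scatter) and so goes below the earlier floor set by compound 1. The same group stands well apart from the other two substituents on this nitrogen, with a 24-fold lower number from compound 2 to compound 4 (1.38 log units; beyond the scatter) and a 130-fold lower number from compound 3 to compound 4 (2.12 log units; beyond the scatter) in this series, so a carbonyl-bearing group on this nitrogen does not by itself produce the drop, as compound 2 shows. Nothing on hand explains the lower number.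

Open, from the compounds shown here alone, is whether the drop needs the 1-methylethenyl end, which a saturated isopropyl or a plain methyl at that end would test. Also open, going by these compounds, is how a simple carbamoyl or a longer acylcarbamoyl chain on this nitrogen would read.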